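Trimming the ethyl to methyl on the aromatic ring

The compounds below may be only part of what the source reports. "The series", "measured", "known", "first", "only" and "open" are said of these compounds alone.

Measured compounds:
compound 1 `CCc1cc(N(CC)CC)ccc1NC(=O)c1c(-c2c(Cl)cccc2Cl)noc1C` — 370 nM
compound 2 `CCN(CC)c1ccc(NC(=O)c2c(-c3c(Cl)cccc3Cl)noc2C)cc1Cl` — > 10000 nM

For the measured compounds named here, in an assay on isolated protein for binding affinity to growth hormone secretagogue receptor type 1 (Homo sapiens) (on this read-out lower numbers stand for stronger inhibition and higher numbers for weaker inhibition), compound 1 gives 370 nM, which is the only numerical value among the two measured compounds. Compound 2 reaches only > 10000 nM in this assay, a limit rather than a number, as it stands at the limit of > 10000 nM in this assay, at which 1 of the 2 values shown sits. Going by the values given here, no pair of measured compounds differs in a single place, so no measured step is available.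

Compound 3 `CCN(CC)c1ccc(NC(=O)c2c(-c3c(Cl)cccc3Cl)noc2C)c(C)c1` differs from compound 1 by hydrogen in place of methyl on a saturated chain carbon bound to an aromatic carbon. The smaller saturated chain keeps the rest of the shared core unchanged. Among the compounds with values here, with no measured step to draw on, the change from compound 1 to compound 3 is expected to stay within the usual scatter of this assay or to weaken binding only slightly, and the expected step is a 1.6-fold higher number from compound 1 to compound 3 (0.21 log units; within the scatter). Compound 3 is therefore estimated at 600 nM in this assay, with a range from 150 nM to 3000 nM.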

Compound 3, half-maximal inhibitory concentration: 37 nM
Compound 3: middle estimate off by 16-fold (1.21 log units), on the high side; the measured number lies below the stated range.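

In this assay, the change from ethyl to methyl brings a 10-fold lower number from compound 1 to compound 3 (1.00 log units; beyond the scatter). This is the only measured step among the compounds shown, and it shows that the loss of a single carbon, on a saturated chain carbon bound to an aromatic carbon, is enough to move binding beyond the scatter, with the smaller group giving the lower number. Nothing measured here gives a reason for this step.

From the compounds shown here alone, it remains open whether the trend continues or reverses with other groups at this place, such as a hydrogen, a methoxy group or a longer chain such as propyl. Compound 2, whose > 10000 nM is a limit, differs from both compound 1 and compound 3 in more than one place, so it cannot settle this.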